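Phenyl for (tert-butoxycarbonyl)amino: notes on compound 3

This account rests on a few compounds, and the source may have more. Where it says the series, first, only, none or still open, it means among the compounds named here.

In a functional assay on SK-OV-3 cells (Homo sapiens) for antiproliferative activity, read by MTT assay, with a stated time of 72 h (on this read-out higher numbers stand for weaker inhibition and lower numbers for stronger inhibition), compound 1 `COc1ccc(NC(=O)CCc2cccc3c2B(O)OC3)cc1` gives 900 nM. Compound 2 `CC(C)(C)OC(=O)Nc1ccc(NC(=O)CCc2cccc3c2B(O)OC3)cc1` gives > 100000 nM, which is a limit and not a number. Compound 3 `O=C(CCc1cccc2c1B(O)OC2)Nc1ccc(-c2ccccc2)cc1` is reached from compound 2 by phenyl in place of (tert-butoxycarbonyl)amino on an aromatic carbon. Among the compounds with values here, the only measured step that bears on this change is an at least 110-fold higher number from compound 1 to compound 2 (2.04 log units; beyond the scatter), which also concerns the (tert-butoxycarbonyl)amino group. On these data alone, with that step as the guide, a large move towards stronger inhibition is expected on losing this group, though phenyl itself is untested. The expected change is an at least 33-fold lower number from compound 2 to compound 3 (1.52 log units; beyond the scatter). For compound 3 the estimate is 3000 nM, with an expected range of 500 nM to 30000 nM.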

Compound 3, half-maximal inhibitory concentration: 48000 nM
Estimate against measurement, compound 3: 16-fold (1.20 log units) below; measured number above the stated range.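

Phenyl in place of (tert-butoxycarbonyl)amino gives an at least 2.0-fold lower number from compound 2 to compound 3 (0.31 log units; beyond the scatter), so losing that group recovers only part of the ground. Phenyl in place of methoxy gives a 53-fold higher number from compound 1 to compound 3 (1.73 log units; beyond the scatter), which shows that the loss at this aromatic carbon is not confined to the (tert-butoxycarbonyl)amino group: compounds 2 and 3 both stand well behind compound 1. The first step is bounded on one side only, since compound 2 gives a limit and not a number: the limit of > 100000 nM in this assay, at which 1 of the 3 values shown sits.

On these data alone, whether an amine, a hydroxyl or an ethyl group here would hold the level of compound 1 stays open. Three groups also cannot show which feature of methoxy matters.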